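Indole hydrazone series: compound 1 to compound 3

The source may report more compounds than this note shows. Statements on the series, on what has been measured and on what is new or still open speak of the compounds shown alone.

Compound 1 `COc1ccc(Cn2cc(/C=N\NC(=O)c3c[nH]c4ccc(Br)cc34)c3ccc(F)cc32)cc1` sits at a limit in a functional assay on LNCaP cells (Homo sapiens) for cytotoxicity; on this read-out higher numbers stand for weaker inhibition and lower numbers for stronger inhibition: compound 1 gives > 100000 nM, one of the values at the limit of > 100000 nM in this assay, at which 1 of the 2 values shown sits. Compound 2 `O=C(N/N=C\c1cn(Cc2ccc(Cl)cc2)c2cc(F)ccc12)c1c[nH]c2ccc(Br)cc12` gives 24800 nM in this assay, and the step with chloro in place of methoxy on an aromatic carbon is an at least 4.0-fold lower number from compound 1 to compound 2 (0.60 log units; beyond the scatter). Compound 3 `COc1ccc(Cn2cc(/C=N\NC(=O)c3cn(C)c4ccccc34)c3ccc(F)cc32)cc1` differs from compound 1 by 1-methyl-1H-indol-3-yl in place of 5-bromo-1H-indol-3-yl on a carbonyl carbon. Among the measured compounds shown here, no measured step touches that change, so nothing supports movement beyond the scatter. Compound 3 is expected to stay weak, with a number no higher from compound 1 to compound 3 (the limit leaves the size open), at an estimated 100000 nM within 30000 nM to 300000 nM.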

Compound 3, half-maximal inhibitory concentration: 9600 nM
Estimate against measurement, compound 3: 10-fold (1.02 log units) above; the measured number lies below the stated range.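

The group on the carbonyl carbon proves to be a second place in the series where this assay responds, not only the aromatic carbon that carries methoxy or chloro: 1-methyl-1H-indol-3-yl in place of 5-bromo-1H-indol-3-yl gives an at least 10-fold lower number from compound 1 to compound 3 (1.01 log units; beyond the scatter) with the methoxy group kept. Going by these compounds, the full size of this step stays unknown, since compound 1 sits at a limit: the limit of > 100000 nM in this assay, at which 1 of the 3 values shown sits.

The change removes bromine and adds a methyl group together, so the shares of the two remain unresolved. On these data alone, how an amine or a carboxylic acid on this indole would read out also remains open.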